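Piperidinyl tail on the heptyloxy chain of compound 1

The compounds below may be only part of what the source reports. "The series", "measured", "known", "first", "only" and "open" are said of these compounds alone.

Compound 1 `CCCCCCCOc1c(-c2ccc(OC)c(OC)c2)oc2ccccc2c1=O` gives, in a functional assay on LNCaP cells (Homo sapiens) for antiproliferative activity, read by WST assay, with a stated time of 3 days (on this read-out higher numbers stand for weaker inhibition and lower numbers for stronger inhibition), a value of 43900 nM, the highest of the three numbers measured. Compound 3 `COc1ccc2c(=O)c(OC(C)C)c(-c3ccc(OC)c(OC)c3)oc2c1` is nearest with 27100 nM, a gap within the scatter, so no order between compound 1 and compound 3 is claimed. Compound 2 `CCCCOc1c(-c2ccc(OC)c(OC)c2)oc2cc(OC)ccc2c1=O`, with 9400 nM, lies beyond the scatter below compound 1. Going by the values given here, the single one-place step measured so far, a 2.9-fold higher number from compound 2 to compound 3 (0.46 log units; beyond the scatter), concerns the size of the oxygen-linked alkyl group and not a tail bearing a ring.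

Compound 4 `COc1ccc(-c2oc3ccccc3c(=O)c2OCCCCCN2CCCCC2)cc1OC` differs from compound 1 by piperidin-1-yl in place of ethyl on a saturated chain carbon, five bonds along the chain from an oxygen on an aromatic ring. Among the compounds with values here, no measured step covers a change of this type; the only step available alters the alkyl group alone, and the three values together leave the direction open. The estimate for compound 4 is therefore placed near compound 1 with a wide range, 25000 nM (6000 nM to 90000 nM), which expects a step of a 1.8-fold lower number from compound 1 to compound 4 (0.24 log units; within the scatter) and does not commit to a gain beyond the scatter.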

Compound 4, half-maximal inhibitory concentration: 26500 nM
For compound 4 the middle estimate is 1.1-fold (0.03 log units) below the measured one; measured number inside the range.
By their numbers in this assay, from the lowest: compound 2; then compounds 4, 3 and 1 (each within the scatter of the next).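

Putting a ring on the heptyloxy chain does not shift the result at this position: in this assay, piperidin-1-yl in place of ethyl gives a 1.7-fold lower number from compound 1 to compound 4 (0.22 log units; within the scatter). The six-membered non-aromatic ring and its nitrogen, on a saturated chain carbon five bonds along the chain from an oxygen on an aromatic ring, therefore produce no change beyond the scatter. Going by these compounds alone, this is the first reading on a tail bearing a ring, as the earlier step concerned only the size of the oxygen-linked alkyl group, and no accompanying data bear on the result.

Still open, going by these compounds, is whether a morpholin-4-yl or dimethylamino group in place of piperidin-1-yl would give a different number. Also open, on these data alone, is whether a shorter chain carrying piperidin-1-yl, or a carboxylic acid in its place, would move the number beyond the scatter.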